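A few compounds are considered here, and "the series" means these few. Any claim that something is new, unique, unknown or untested is made for them only; others in the source may bear on it.

Measured so far in an assay on isolated protein for inhibition of protein kinase C zeta type (Homo sapiens), with stated times of 1 h and 2.5 min, tested at 30 uM; on this read-out lower numbers stand for less inhibition and higher numbers for more inhibition at the one concentration tested (going by the name of the read-out):
Compound 1, `Cc1cccc(-c2csc(N)c2C(=O)OCc2ccccc2)c1`: 68%
Compound 2, `Nc1scc(-c2cccc(C(F)(F)F)c2)c1C(=O)OCc1ccccc1`: 29%

Of these two numbers compound 2 stands lowest; its nearest neighbour, compound 1, lies a long way higher, a gap beyond the usual scatter. Compound 3, `N#Cc1cccc(-c2csc(N)c2C(=O)OCc2ccccc2)c1`, has not yet been measured. It differs from compound 2 in one place: cyano in place of trifluoromethyl on an aromatic carbon. Going by the values given here, only one measured step touches this position, and it was a large one: a number 39 percentage points lower from compound 1 to compound 2 (beyond the scatter). That step shows that a change at this position can move the read-out a great deal, but it compares methyl with trifluoromethyl, whereas here cyano takes the place of trifluoromethyl, so its direction carries over only loosely. A moderate rise is expected, placing compound 3 between its two neighbours, a number 13 percentage points higher from compound 2 to compound 3 (beyond the scatter). Compound 3 is therefore estimated at 42% in this assay, with a range from 15% to 65%.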

Compound 3, a percentage reported as inhibition, at one concentration (the size of the read-out at that concentration, not a potency): 25%
Estimate against measurement, compound 3: 17 percentage points above; the range from low to high includes it.
By their numbers in this assay, from the lowest: compounds 3 and 2 (each within the scatter of the next); then compound 1.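

In this assay there is a number 4 percentage points lower from compound 2 to compound 3 (within the scatter) when cyano takes the place of trifluoromethyl, so on this read-out these two groups cannot be told apart, even though they differ in heavy atoms and hydrogen-bond acceptors. With cyano in place of methyl there is a number 43 percentage points lower from compound 1 to compound 3 (beyond the scatter), much like a number 39 percentage points lower from compound 1 to compound 2 (beyond the scatter), so among these three compounds the large drop goes with losing methyl, whichever of the other two groups enters. No measurement is at hand that would explain why methyl stands apart.

Still open, from the compounds shown here alone, is how an amine, a methoxy group or a carboxylic acid would read at this place on the ring. Also open, going by these compounds, is whether a longer chain such as ethyl would keep the higher number seen with methyl.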